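Swapping Methoxy and Chloro on an Oxime Scaffold

A few compounds are considered here, and "the series" means these few. Any claim that something is new, unique, unknown or untested is made for them only; others in the source may bear on it.

Of the compounds shown here, three have been measured in a functional assay (Mus musculus, strain Balb/c) for inhibition, read by ELISA, with a stated time of 72 h; on this read-out lower numbers stand for stronger inhibition and higher numbers for weaker inhibition. Compound 1 `COc1ccc(C(=O)/C=C/c2ccc(Br)cc2)cc1` gives 25100 nM. Compound 2 `COc1ccc(C(/C=C/c2ccc(Cl)cc2)=N/O)cc1` gives 11500 nM, and compound 3 `O/N=C(\C=C\c1ccc(Cl)cc1)c1ccc(Cl)cc1` gives 9150 nM, the lowest of the three numbers, with compound 2 lying within the scatter of it and compound 1 lying beyond. Compound 4 `COc1ccc(/C=C/C(=N\O)c2ccc(Cl)cc2)cc1` differs from compound 3 by methoxy in place of chloro on an aromatic carbon. Within the data shown here, only one measured step bears on this change, the reverse exchange a 1.3-fold lower number from compound 2 to compound 3 (0.10 log units; within the scatter), which stayed within the scatter. On that precedent, no shift beyond the scatter is expected. The expected step is a 1.1-fold higher number from compound 3 to compound 4 (0.04 log units; within the scatter), small in either direction. Compound 4 is therefore estimated at 10000 nM, within a range from 5000 nM to 20000 nM.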

Compound 4, half-maximal inhibitory concentration: 5850 nM
Estimate against measurement, compound 4: 1.7-fold (0.23 log units) above; the measured number falls inside the stated range.
By their numbers in this assay, from the lowest: compounds 4, 3 and 2 (each within the scatter of the next); then compound 1.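

The change from chloro to methoxy on this aromatic carbon gives a 1.6-fold lower number from compound 3 to compound 4 (0.19 log units; within the scatter) and so stays within the scatter. The earlier exchange between these two groups, a 1.3-fold lower number from compound 2 to compound 3 (0.10 log units; within the scatter), lay on the other aromatic ring, so neither ring has yet shown a real difference between chloro and methoxy. Nothing measured here offers an explanation for these close numbers.

Still open, on these data alone, is whether a larger change at this position would shift the number beyond the scatter. An amine, a carboxylic acid or a longer chain such as butoxy could test this.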